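The source may report more compounds than this note shows. Statements on the series, on what has been measured and on what is new or still open speak of the compounds shown alone.

Measured in an ADME assay on L929 cells (Mus musculus) for cytotoxicity, read by resazurin assay, with a stated time of 72 h; a higher number here means a weaker inhibitor, a lower number a stronger inhibitor:
- compound 1 `O=C(/C=C/c1ccc2c(c1)B(O)OC2)c1ccc(OCc2ccccc2)cc1`: > 10 ug/mL (a limit of the assay)
- compound 2 `COc1cccc(C(=O)/C=C/c2ccccc2)c1`: 5.7 ug/mL
- compound 3 `Cc1ccc(C(=O)/C=C/c2ccc3c(c2)B(O)OC3)cc1C`: > 10 ug/mL (a limit of the assay)

Compound 1 has no actual number in this assay, only a limit. It stands at the limit of > 10 ug/mL in this assay, at which 2 of the 3 values shown sit. For the measured compounds named here, compound 2 gives the one actual number in the set, 5.7 ug/mL.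

The step now followed leads to compound 4 `O=C(/C=C/c1ccc2c(c1)B(O)OC2)c1ccc(F)cc1`, which keeps the core of compound 1 and differs at one place: fluoro in place of benzyloxy on an aromatic carbon. Going by the values given here, no pair of measured compounds shows a change of this kind, so the expectation rests on few data.

Compound 3 carries the same core as compound 1. Compound 3 also ends at a limit, > 10 ug/mL. With that in view, no step beyond the usual scatter is expected in this assay, and a reported limit is the likelier outcome for compound 4. The expected change is a step that the limit leaves unreadable from compound 1 to compound 4. The lower end of the range allows for compound 2, which has a different core and gives 5.7 ug/mL. For compound 4 the estimated value is 11 ug/mL. The estimated range for compound 4 runs from 5 ug/mL to 22 ug/mL.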

Compound 4, half-maximal inhibitory concentration: > 10 ug/mL
Compound 4: no number, only a limit (the forecaster's own chance of this, stated with the estimate: 65%); the middle value lies beyond the limit too.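

In this assay compound 4 gives > 10 ug/mL, a limit of the assay. Compound 1 also ends at a limit, and the step from benzyloxy to fluoro between compound 1 and compound 4 cannot be read. The compounds shown leave open the actual values of compound 1 and compound 4, and whether this change alters cytotoxicity at all.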